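The source may report more compounds than this note shows. Statements on the series, on what has been measured and on what is new or still open speak of the compounds shown alone.

In an ADME assay on MDBK cells (Bos taurus) for cytotoxicity, read by MTT assay (on this read-out higher numbers stand for lower toxicity in this test and lower numbers for higher toxicity in this test), compound 3 `CC(C)(C)C(=O)N(CCCCCCN1C[C@H](O)[C@@H](O)[C@H](O)[C@H]1CO)c1cc(F)ccc1F` gives > 500000 nM, which is a limit of the assay rather than a measured number. Compound 1 `CC1CCCCC1N(CCCCCCN1C[C@H](O)[C@@H](O)[C@H](O)[C@H]1CO)C(=O)C(C)(C)C` also reaches only a limit in this assay, > 500000 nM. Compound 2 `CC(C)(C)C(=O)N(CCCCCCN1C[C@H](O)[C@@H](O)[C@H](O)[C@H]1CO)C1CCCCC1` likewise stops at a limit, > 500000 nM. Because of the limit of > 500000 nM in this assay, at which 3 of the 3 values shown sit, the steps a step that the two limits leave unreadable from compound 1 to compound 2, a step that the two limits leave unreadable from compound 1 to compound 3 and a step that the two limits leave unreadable from compound 2 to compound 3 cannot be given a size. Compound 4 `CC(C)(C)C(=O)N(CCCCCCN1C[C@H](O)[C@@H](O)[C@H](O)[C@H]1CO)C1CC1` differs from compound 3 by cyclopropyl in place of 2,5-difluorophenyl on an amide-type nitrogen. Among the compounds with values here, with no measured step readable, no shift beyond the scatter is expected in either direction, and the expected step is a step that the limit leaves unreadable from compound 3 to compound 4. Compound 4 is therefore estimated at 600000 nM in this assay, with a plausible range from 300000 nM to 1500000 nM, and most probably it will again be reported only as a limit.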

Compound 4, half-maximal cytotoxic concentration: > 500000 nM
Compound 4 ended at the assay's limit; the forecaster's own chance of this, stated with the estimate: 85%; the middle value lies beyond the limit too.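

The steps between compound 4 and compounds 1, 2 and 3 cannot be given a size, because all four compounds stop at the same value, which is a limit and not a measured number: the limit of > 500000 nM in this assay, at which 4 of the 4 values shown sit.

On these data alone, whether these four compounds differ in toxicity to the cells, and at what concentration any of them would become toxic, remains open.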